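This account rests on a few compounds, and the source may have more. Where it says the series, first, only, none or still open, it means among the compounds named here.

Among the measured compounds shown here, in a functional assay on MGC-803 cells (Homo sapiens) for cytotoxicity, read by MTT assay, with a stated time of 72 h (on this read-out higher numbers stand for weaker inhibition and lower numbers for stronger inhibition), compound 1 `CN(C)c1ccc(C=C2C(=O)N(c3ccc(Cl)cc3)N(c3ccc(Cl)cc3)C2=O)cc1` gives 80200 nM and compound 2 `O=C1C(=Cc2ccc(F)cc2)C(=O)N(c2ccc(Cl)cc2)N1c1ccc(Cl)cc1` gives 26000 nM, the lower of the two numbers so far. Compound 3 `O=C1C(=Cc2ccc(Cl)cc2)C(=O)N(c2ccc(Cl)cc2)N1c1ccc(Cl)cc1` differs from compound 2 by chloro in place of fluoro on an aromatic carbon. For the measured compounds named here, the only measured step at this place, a 3.1-fold lower number from compound 1 to compound 2 (0.49 log units; beyond the scatter), is modest and exchanges a different pair of groups, so no step beyond the scatter is expected in this assay. The estimated change is a 1.3-fold lower number from compound 2 to compound 3 (0.11 log units; within the scatter). Compound 3 is expected at 20000 nM, with an estimated range of 8000 nM to 50000 nM.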

Compound 3, half-maximal inhibitory concentration: 32600 nM
For compound 3 the middle estimate is 1.6-fold (0.21 log units) below the measured one, within the range that was stated.
By their numbers in this assay, from the lowest: compounds 2 and 3 (each within the scatter of the next); then compound 1.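

In this assay, chloro in place of fluoro gives a 1.3-fold higher number from compound 2 to compound 3 (0.10 log units; within the scatter) and so leaves the number at this position unresolved between the two halogens. Chloro in place of dimethylamino gives a 2.5-fold lower number from compound 1 to compound 3 (0.39 log units; beyond the scatter) and thus sides with the fluoro step, as both halogens give numbers beyond the scatter of compound 1. No measurement bears on the reason for these results. The compounds shown leave open how a methoxy group, a nitrile or a carboxylic acid would read at this position. They also leave open whether these steps hold when other parts of the shared core change.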